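The source may report more compounds than this note shows. Statements on the series, on what has been measured and on what is new or still open speak of the compounds shown alone.

Measured in a physicochemical assay for solubility, in phosphate buffer, at pH 7.4; on this read-out lower numbers stand for lower solubility and higher numbers for higher solubility:
- compound 1 `Cc1cc(C)c(NC(=O)c2sccc2S(=O)(=O)Nc2onc(C)c2Cl)c(C)c1`: 23000 ug/mL
- compound 2 `Cc1cc(C)c(N(C)C)c(C)c1NC(=O)c1sccc1S(=O)(=O)Nc1onc(C)c1Cl`: 50000 ug/mL
- compound 3 `COc1c(C)cc(C)c(NC(=O)c2sccc2S(=O)(=O)Nc2onc(C)c2Cl)c1C`: < 10000 ug/mL, a limit and not a number

Compound 3 has no exact position in this assay, only (the limit of < 10000 ug/mL in this assay, at which 1 of the 3 values shown sits). Compound 4 `Cc1cc(C)c(NC(=O)c2sccc2S(=O)(=O)Nc2onc(C)c2Cl)c(C)c1CO` differs from compound 3 in one place: hydroxymethyl in place of methoxy on an aromatic carbon. Hydroxymethyl takes the place of methoxy on an aromatic carbon, ortho to two methyl groups and para to a methyl group.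

For the measured compounds named here, no measured step has hydroxymethyl entering, so the evidence is indirect. Going by the values given here, the steps that bear on this change are those at the same carbon. Methoxy in place of hydrogen gave an at least 2.3-fold lower number from compound 1 to compound 3 (0.36 log units; beyond the scatter), and methoxy in place of dimethylamino gave an at least 5.0-fold lower number from compound 2 to compound 3 (0.69 log units; beyond the scatter). Dimethylamino in place of hydrogen gave a 2.2-fold higher number from compound 1 to compound 2 (0.34 log units; beyond the scatter), which is modest. Methoxy therefore accompanies the lowest reading of the three, and both other compounds stand clearly higher. On that basis, a modest rise is expected when methoxy leaves, bringing compound 4 back towards compound 1 at 23000 ug/mL. The expected change is an at least 2.0-fold higher number from compound 3 to compound 4 (0.30 log units; that floor lies within the scatter), though its size is uncertain since the starting point is only a limit. For compound 4 the estimate is 20000 ug/mL, with an expected range from 8000 ug/mL to 45000 ug/mL.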

Compound 4, solubility: 65000 ug/mL
The estimate for compound 4 lay 3.3-fold (0.51 log units) below the measured number; measured number above the stated range.
By their numbers in this assay, from the lowest: compound 1; then compounds 2 and 4 (each within the scatter of the next). At a limit, below all of these: compound 3.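

In this assay, replacing methoxy with hydroxymethyl keeps the same atoms, joined differently, and brings in a hydrogen-bond donor that methoxy lacks; that single change gave an at least 6.5-fold higher number from compound 3 to compound 4 (0.81 log units; beyond the scatter). For the compounds shown here, measured against hydrogen at the same carbon, hydroxymethyl gave a 2.8-fold higher number from compound 1 to compound 4 (0.45 log units; beyond the scatter), so dimethylamino is no longer the only group here with a reading beyond the scatter above compound 1, while methoxy still goes the other way. Hydroxymethyl in place of dimethylamino gave a 1.3-fold higher number from compound 2 to compound 4 (0.11 log units; within the scatter), so these two groups cannot be told apart in this assay, although only dimethylamino has a nitrogen at this carbon.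

From the compounds shown here alone, compound 3 stands only as a limit and not as a number, so the full size of the step from it remains open: the limit of < 10000 ug/mL in this assay, at which 1 of the 4 values shown sits. Going by these compounds, it also remains open whether the hydroxyl hydrogen goes with the higher reading, a question that a longer chain such as hydroxyethyl, a carboxylic acid or a primary amine at this same carbon would help to answer.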